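The source may hold more compounds than are shown below. What is called first, only, known or untested is meant among the compounds shown, and "the series" means these compounds.

In a functional assay on Huh-7 cells (Homo sapiens) for cytotoxicity, with a stated time of 48 h (a lower number here means a stronger inhibitor, a higher number a weaker inhibitor), compound 1 `COc1cc(O)c(C(=O)/C=C/c2ccc(F)cc2)c(OC)c1` reports only a limit, > 20000 nM. Compound 2 `COc1cc(OC)c(C(=O)/C=C/c2ccccc2OC)c(OC)c1` gives 9800 nM, and compound 3 `COc1cc(OC)c(C(=O)/C=C/c2ccc(Cl)cc2)c(OC)c1` gives 12700 nM. Compound 3 therefore stands level with compound 2, within the scatter. Within the data shown here, the one measured step, a 1.3-fold higher number from compound 2 to compound 3 (0.11 log units; within the scatter), changes the group in question and moves the number by no more than the scatter.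

Compound 4 `COc1cc(OC)c(C(=O)/C=C/c2ccc(Br)cc2)c(OC)c1` has not yet been measured. It differs from compound 3 in one place, bromo in place of chloro on an aromatic carbon, para to a large group. Among the measured compounds shown here, no measured pair shows this exchange directly. The closest guide is the step into compound 3, a 1.3-fold higher number from compound 2 to compound 3 (0.11 log units; within the scatter), where a larger change of group at that end of the molecule stayed within the scatter. A step beyond the scatter in this assay is therefore not expected, and the estimated step is a 1.1-fold lower number from compound 3 to compound 4 (0.02 log units; within the scatter). For compound 4 the estimated value is 12000 nM, with an expected range from 6000 nM to 20000 nM.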

Compound 4, half-maximal inhibitory concentration: 13900 nM
Compound 4: middle estimate off by 1.2-fold (0.06 log units), on the low side; measured number inside the range.
By their numbers in this assay, from the lowest: compounds 2, 3 and 4 (each within the scatter of the next). At a limit, above all of these: compound 1.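

Bromo in place of chloro on the aromatic carbon, para to a large group, gives in this assay a 1.1-fold higher number from compound 3 to compound 4 (0.04 log units; within the scatter), so this position shows no separation between these two halogens. Set against the 2-methoxyphenyl group, the 4-bromophenyl group gives a 1.4-fold higher number from compound 2 to compound 4 (0.15 log units; within the scatter), which places a third group at this end of the molecule level with the other two, a finding limited to compounds 2, 3 and 4. The data shown offer no measured property that bears on this closeness.

From the compounds shown here alone, whether an amine or a carboxylic acid at this same place would carry the number beyond the scatter remains open. Compound 1 gives only a limit, > 20000 nM, and so supplies no number for comparison.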